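The source may report more compounds than this note shows. Statements on the series, on what has been measured and on what is new or still open speak of the compounds shown alone.

Of the compounds shown here, three built on one shared core have been tested in a functional assay on PC-3 cells (Homo sapiens) for inhibition, read by sulforhodamine B assay, with a stated time of 48 h, tested at 10 uM; on this read-out higher numbers stand for more inhibition at the one concentration tested (going by the name of the read-out) and lower numbers for less inhibition. Compound 1 `c1ccc(-c2cn3ccnc3c(-c3ccc4ncn(C5CCCCC5)c4c3)n2)cc1` gives 92% in this assay. Compound 2 `COc1ccc(-c2cn3ccnc3c(-c3ccc4ncn(C5CCCCC5)c4c3)n2)cc1` gives 95.2%, and the step of a number 3.2 percentage points higher from compound 1 to compound 2 (within the scatter) lies within the scatter. Compound 3 `O=Cc1ccc(-c2cn3ccnc3c(-c3ccc4ncn(C5CCCCC5)c4c3)n2)cc1` gives 19%, the lowest of the three numbers, with compounds 1 and 2 both standing above it by amounts beyond the scatter. Compound 4 `c1cn2cc(-c3ccsc3)nc(-c3ccc4ncn(C5CCCCC5)c4c3)c2n1` differs from compound 3 by one exchange: thiophen-3-yl in place of 4-formylphenyl on an aromatic carbon. The measured steps that bear on this change are the two that brought the formyl in, a number 73 percentage points lower from compound 1 to compound 3 (beyond the scatter) and a number 76.2 percentage points lower from compound 2 to compound 3 (beyond the scatter), both large. Compound 4 takes away the 4-formylphenyl entirely, while the entering thiophen-3-yl has no measured counterpart among these compounds, so its own contribution is unknown. Inhibition in this assay is expected to rise by about a number 56 percentage points higher from compound 3 to compound 4 (beyond the scatter), with a wide range owing to the untested ring. Compound 4 is estimated at 75%, between 40% and 95%.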

Compound 4, a percentage reported as inhibition, at one concentration (the size of the read-out at that concentration, not a potency): 19.9%
The estimate for compound 4 lay 55.1 percentage points above the measured number; measured number below the stated range.
By their numbers in this assay, from the lowest: compounds 3 and 4 (each within the scatter of the next); then compounds 1 and 2 (each within the scatter of the next).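

In this assay, the low reading of compound 3 proves not to be unique to its 4-formylphenyl group: exchanging that whole group for thiophen-3-yl gives a number 0.9 percentage points higher from compound 3 to compound 4 (within the scatter), so two quite different groups at this position stand level. A small-looking ring exchange from the unsubstituted phenyl gives a number 72.1 percentage points lower from compound 1 to compound 4 (beyond the scatter), and the exchange from 4-methoxyphenyl gives a number 75.3 percentage points lower from compound 2 to compound 4 (beyond the scatter), so high inhibition here is not kept by every aromatic ring placed on this carbon. Nothing available explains why these two groups read so much lower than phenyl and 4-methoxyphenyl.

On these data alone, it remains open whether the ring size, the sulfur atom or the attachment point of the thiophene sets this result. A pyridine ring, or a phenyl carrying an amine or a carboxylic acid, could help separate these possibilities.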